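A few compounds are considered here, and "the series" means these few. Any claim that something is new, unique, unknown or untested is made for them only; others in the source may bear on it.

In an ADME assay on cells (Fibroblast, Homo sapiens) for antiproliferative activity, with a stated time of 48 h (on this read-out lower numbers stand for stronger inhibition and higher numbers for weaker inhibition), compound 1 `CCOC(=O)c1ccc(-c2ccc(N(CC)CC)nn2)cc1` gives 3000 nM. Compound 2 `CCOC(=O)c1ccc(-c2ccc(N(C)C)nn2)cc1` stands at > 25000 nM, which is a limit of the assay and not a number. Its place on the scale is therefore (the limit of > 25000 nM in this assay, at which 1 of the 2 values shown sits). Compound 3 `CCOC(=O)c1ccc(-c2ccc(OCC)nn2)cc1` carries ethoxy in place of dimethylamino on an aromatic carbon. Among the compounds with values here, one measured step bears on this change: dimethylamino in place of diethylamino on an aromatic carbon gave an at least 8.3-fold higher number from compound 1 to compound 2 (0.92 log units; beyond the scatter). Within the data shown here, that step shows that this assay can respond strongly to a change in this group, but it includes no ethoxy compound and ends at a limit. Only a modest move toward a lower number is therefore expected, and it may not exceed the scatter. The expected step is an at least 2.0-fold lower number from compound 2 to compound 3 (0.31 log units; beyond the scatter). Compound 3 is estimated at 12000 nM, with an expected range of 3500 nM to 30000 nM.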

Compound 3, half-maximal inhibitory concentration: > 25000 nM
Compound 3 was reported as a limit (the forecaster's own chance of this, stated with the estimate: 40%); middle value at least 2.0-fold (0.31 log units) away from the limit.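

Compound 3 stands at > 25000 nM in this assay, which is a limit of the assay and not a number. Ethoxy in place of diethylamino gives an at least 8.3-fold higher number from compound 1 to compound 3 (0.92 log units; beyond the scatter), so the weaker read-out at this position is now seen with an oxygen-linked group as well as with dimethylamino, and not with the amine alone. The step between compound 2 and compound 3 cannot be read, and compound 1 is the only compound shown with a measured number: the limit of > 25000 nM in this assay, at which 2 of the 3 values shown sit.

From the compounds shown here alone, it remains open whether the nitrogen or the size of the group matters more in compound 1; a dipropylamino, pyrrolidine or propoxy group at this position would test this. Also open, going by these compounds, is how a carboxylic acid or an amide in place of the ethyl ester would read out with diethylamino retained.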